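The source may hold more compounds than are shown below. What is called first, only, known or untested is meant among the compounds shown, and "the series" means these compounds.

Of the compounds shown here, two have so far been measured in a functional assay on MCF7 cells (Homo sapiens) for cytotoxicity, read by sulforhodamine B assay, with a stated time of 48 h; a lower number here means a stronger inhibitor, a higher number a weaker inhibitor. In this test, compound 1 `COc1cc(/C=C/C(=O)c2ccc(N)c(-c3ccc(F)cc3)c2)cc(Br)c1O` gives 40500 nM, while compound 2 `O=C(/C=C/c1ccc(Br)cc1)c1cccc(-c2cccc(F)c2)c1` gives 18300 nM. Compound 2 therefore holds the lower of the two numbers, and its gap to compound 1 lies beyond the usual scatter. These two compounds differ in more than one place, so the gap cannot be tied to any single group.

The next compound is compound 3 `O=C(/C=C/c1cccc(Br)c1)c1cccc(-c2cccc(F)c2)c1`, which has the same atoms as compound 2, joined differently: 3-bromophenyl in place of 4-bromophenyl on a double-bonded chain carbon bound to a double-bonded chain carbon. It carries 3-bromophenyl in place of 4-bromophenyl on a double-bonded chain carbon bound to a double-bonded chain carbon. Within the data shown here, no measured pair shows a change of this kind, so the expectation rests only on compound 2 and its value of 18300 nM. No change beyond the scatter is expected, and neither direction is favoured with any confidence. The estimated step of a 1.1-fold lower number from compound 2 to compound 3 (0.03 log units; within the scatter) is accordingly small. For compound 3, the estimated value is 17000 nM, with an expected range of 7000 nM to 40000 nM.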

Compound 3, half-maximal inhibitory concentration: 12700 nM
Estimate against measurement, compound 3: 1.3-fold (0.13 log units) above; the measured number falls inside the stated range.
By their numbers in this assay, from the lowest: compounds 3 and 2 (each within the scatter of the next); then compound 1.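

In this assay, among these compounds, the exchange of 4-bromophenyl for 3-bromophenyl on a double-bonded chain carbon bound to a double-bonded chain carbon gives a 1.4-fold lower number from compound 2 to compound 3 (0.16 log units; within the scatter) and provides the first comparison here that can be tied to a single place. Compound 2 and compound 3 carry the same atoms, and this test does not separate them, so on this shared core the two bromophenyl arrangements can be treated as equivalent within the scatter. The result therefore gives no reason to prefer either arrangement, although it rests on one pair alone, and the data shown offer no measurement that could explain it.

From the compounds shown here alone, it remains open whether the two bromophenyl groups would stay this close if the fluorophenyl part of the shared core were changed, or in another assay. Going by these compounds, it is also open whether a nitrile, a carboxylic acid or an amine in place of the bromine on this phenyl ring would move the number beyond the scatter, since a single exchange of one bromophenyl for the other says nothing about a different group at this place.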